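Aryl swap at the imidazole-side chain carbon: compound 3 to 4

A few compounds are considered here, and "the series" means these few. Any claim that something is new, unique, unknown or untested is made for them only; others in the source may bear on it.

Measured so far in an in vitro functional assay on cells for agonist activity at Bombesin receptor subtype-3 (Homo sapiens), read by luminescence and calcium flux; a higher number here means that more compound is needed for the effect, a lower number that less compound is needed:
compound 1, `O=C(O)c1ccccc1-c1ccc(CCc2ncc(CC3CCC3)[nH]2)cc1`, gives 588 nM
compound 2, `CC(C)(C)CCc1cnc(CCc2ccc(-c3ccccc3C(=O)O)cc2)[nH]1`, gives 39 nM
compound 3, `COc1cccc(Cc2cnc(CCc3ccc(-c4ccccc4C(=O)O)cc3)[nH]2)c1`, gives 4120 nM

Compound 3 holds the highest number of the three. Its nearest neighbour is compound 1, reached by a 7.0-fold higher number from compound 1 to compound 3 (0.85 log units; beyond the scatter); the furthest is compound 2, reached by a 110-fold higher number from compound 2 to compound 3 (2.02 log units; beyond the scatter). Both steps swap a saturated group for the 3-methoxyphenyl and both raise the number, so the aryl group at this place is the weakest choice seen so far.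

Compound 4, `O=C(O)c1ccccc1-c1ccc(CCc2ncc(Cc3ccc(F)cc3)[nH]2)cc1`, keeps the shared core and differs from compound 3 only in that place: 4-fluorophenyl in place of 3-methoxyphenyl on a saturated chain carbon bound to an aromatic carbon.

Within the data shown here, no measured step exchanges one aryl group for another at this position; the two steps that touch it, from compound 1 and from compound 2, compare saturated groups against the 3-methoxyphenyl and say nothing about how a 4-fluorophenyl would compare with it. The change is therefore expected to stay close to compound 3 in this assay, with a step of about a 1.6-fold lower number from compound 3 to compound 4 (0.22 log units; within the scatter) that may well lie within the scatter, and a wide range either way.

Compound 4 is estimated at 2500 nM, between 500 nM and 12000 nM.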

Compound 4, half-maximal effective concentration: 1600 nM
Compound 4: the middle estimate sits 1.6-fold (0.19 log units) above what was measured, within the range that was stated.
By their numbers in this assay, from the lowest: compound 2; then compound 1; then compound 4; then compound 3.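

Working notes on the position: in this assay the exchange of one aryl group for another gives a 2.6-fold lower number from compound 3 to compound 4 (0.41 log units; beyond the scatter) and so shows that the choice of substituted phenyl at this saturated chain carbon does register, if only modestly. The 4-fluorophenyl still compares poorly with the saturated groups, with a 2.7-fold higher number from compound 1 to compound 4 (0.43 log units; beyond the scatter) against cyclobutyl and a 41-fold higher number from compound 2 to compound 4 (1.61 log units; beyond the scatter) against neopentyl, so both aryl groups shown give higher numbers than both saturated groups shown, and the aryl-for-aryl step is much smaller than the step from neopentyl. Nothing available explains why these groups rank as they do.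

The step from 3-methoxyphenyl to 4-fluorophenyl changes both the substituent and its ring position at once, so the compounds shown cannot separate those two changes; 3-fluorophenyl, 4-methoxyphenyl and unsubstituted phenyl would be the groups to compare. As far as these compounds go, it also remains open whether any aryl group here can approach the number of compound 2, and whether a longer branched alkyl chain than neopentyl would lower the number further.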